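This account rests on a few compounds, and the source may have more. Where it says the series, first, only, none or still open, it means among the compounds named here.

Measured in a physicochemical assay for solubility, measured as kinetic solubility; on this read-out higher numbers stand for higher solubility and lower numbers for lower solubility:
- compound 1 `CCC/N=C1\S/C(=C\c2ccc(O)c(C(F)(F)F)c2)C(=O)N1c1ccccc1C`: 14000 nM
- compound 2 `Cc1ccccc1N1C(=O)/C(=C/c2ccc(O)c(Cl)c2)S/C1=N\CCO`: > 250000 nM
- compound 3 `CCC/N=C1\S/C(=C\c2ccc(O)c(Cl)c2)C(=O)N1C(C)C`: 20000 nM

Compound 1 gives 14000 nM and compound 3 gives 20000 nM. These two numbers lie within the usual scatter of each other, so this small set cannot tell them apart. Compound 2 is reported as > 250000 nM, which is a limit of the assay and not a number.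

The next compound to consider is compound 4 `CCC/N=C1\S/C(=C\c2ccc(O)c(C(C)C)c2)C(=O)N1c1ccccc1C`. It keeps the rest of compound 1 and makes one change: isopropyl in place of trifluoromethyl on an aromatic carbon, ortho to a hydroxy group (isopropyl in place of trifluoromethyl on an aromatic carbon).

Among the measured compounds shown here, none of the measured compounds differs from another in one place only, so no direct example of this swap is available. The best starting point is therefore compound 1 itself, at 14000 nM. In this assay, no change beyond the scatter is expected from this single swap. The expected result is a 1.4-fold lower number from compound 1 to compound 4 (0.15 log units; within the scatter), a small step downward that stays within the usual scatter. For compound 4 the estimated value is 10000 nM, with an expected range of 3000 nM to 35000 nM.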

Compound 4, solubility: 79000 nM
Compound 4: middle estimate off by 7.9-fold (0.90 log units), on the low side; measured number above the stated range.
By their numbers in this assay, from the lowest: compounds 1 and 3 (each within the scatter of the next); then compound 4. At a limit, above all of these: compound 2.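

In this assay, putting isopropyl in place of trifluoromethyl gives a 5.6-fold higher number from compound 1 to compound 4 (0.75 log units; beyond the scatter), and this is the first pair shown that differs in one place only. It shows that the group on this aromatic carbon, ortho to a hydroxy group, can move the solubility number beyond the usual scatter while the rest of compound 1 stays the same. Nothing measured here explains the size or direction of this step.

A single pair cannot show whether the same swap would give a similar step if another part of the molecule were different, such as the propyl chain or the group on the ring nitrogen. It also leaves open where other groups at this position, for example a methoxy group, an amine or a carboxylic acid, would fall relative to isopropyl and trifluoromethyl.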